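This account rests on a few compounds, and the source may have more. Where it says the series, first, only, none or still open, it means among the compounds named here.

The compounds measured in an assay on CHO cells for displacement of a labelled ligand from prostaglandin E2 receptor EP1 subtype (Homo sapiens) (a higher number here means a weaker inhibitor, a lower number a stronger inhibitor), are these. Compound 1 `CCc1ccccc1N(CC(=O)NCc1ccc(OC)c(OC)c1)S(=O)(=O)c1ccc(C)cc1` gives 25.1 nM. Compound 2 `CCc1ccccc1N(CC(=O)NCc1cccc(OC)c1)S(=O)(=O)c1ccc(C)cc1` gives 79.4 nM. Compound 3 `Cc1ccc(S(=O)(=O)N(CC(=O)NCc2ccc(Cl)cc2)c2ccccn2)cc1` is reported only as a limit of the assay, < 1000 nM, so its place among the numbers is not fixed (the limit of < 1000 nM in this assay, at which 1 of the 3 values shown sits).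

For the measured compounds named here, the one step between measured compounds, a 3.2-fold higher number from compound 1 to compound 2 (0.50 log units; beyond the scatter), concerns the amide side of the shared core and leaves the sulfonamide nitrogen untouched. Compound 4 `Cc1ccc(S(=O)(=O)N(CC(=O)NCc2ccc(Cl)cc2)c2ccnn2C)cc1` differs from compound 3 by 1-methyl-1H-pyrazol-5-yl in place of pyridin-2-yl on a sulfonamide nitrogen. No measured step touches this position, so neither the direction nor the size of the change can be read from the numbers shown. Compound 4 is therefore expected to sit near the limit of compound 3, and a value of 400 nM (range 100 nM to 1600 nM) is estimated. The step this estimate implies, a step that the limit leaves unreadable from compound 3 to compound 4, is thus expected to stay within the scatter.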

Compound 4, inhibition constant: 398 nM
Compound 4: the middle estimate sits 1.0-fold (0.00 log units) above what was measured; measured number inside the range.
By their numbers in this assay, from the lowest: compound 1; then compound 2; then compound 4.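

Compound 3 stands in this assay only as a limit of the assay, so no step to compound 4 can be read: the limit of < 1000 nM in this assay, at which 1 of the 4 values shown sits.

The compounds shown leave open whether pyridin-2-yl or 1-methyl-1H-pyrazol-5-yl on a sulfonamide nitrogen gives the lower number.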